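The compounds below may be only part of what the source reports. "The series", "measured", "known", "first", "only" and "open" are said of these compounds alone.

Measured compounds:
Compound 1: `c1ccc(Oc2ccc3c(NCCCNCc4ccco4)ccnc3c2)cc1`, 15200 nM
Compound 2: `COc1cccc(Oc2ccc3c(NCCCNCc4cc(F)ccc4OC)ccnc3c2)c1`, 7100 nM

Of the compounds shown here, two have so far been tested in an ADME assay on HepG2 cells (Homo sapiens) for cytotoxicity, read by luminescence, CellTiter-Glo and ATP content, with a stated time of 72 h; a higher number here means that more compound is needed for the effect, a lower number that less compound is needed. Compound 1 `c1ccc(Oc2ccc3c(NCCCNCc4ccco4)ccnc3c2)cc1` gives 15200 nM in this assay. Compound 2 `COc1cccc(Oc2ccc3c(NCCCNCc4cc(F)ccc4OC)ccnc3c2)c1` gives 7100 nM in this assay. Among the compounds with values here, of these two numbers, the one for compound 1 is the higher, and the gap to compound 2 lies beyond the usual scatter of repeated measurements, so compound 1 needs more compound for the effect than compound 2 does.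

Compound 3 `Fc1ccc(Oc2ccc3c(NCCCNCc4ccco4)ccnc3c2)cc1` has not yet been measured. It differs from compound 1 in a single spot: fluoro in place of hydrogen on an aromatic carbon. Put another way, the phenoxy group of compound 1 becomes a 4-fluorophenoxy group in compound 3, with the rest of the shared core untouched. Within the data shown here, no measured pair in this set shows what such an exchange does in this assay, so the expectation rests on the change being a single added atom. The step from compound 1 to compound 3 is expected to be small, a 1.1-fold lower number from compound 1 to compound 3 (0.04 log units; within the scatter), and not beyond the scatter in either direction. Compound 3 is therefore expected to give about 14000 nM in this assay, within a range from 7000 nM to 30000 nM.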

Compound 3, half-maximal effective concentration: 16000 nM
Estimate against measurement, compound 3: 1.1-fold (0.06 log units) below; the measured number falls inside the stated range.
By their numbers in this assay, from the lowest: compound 2; then compounds 1 and 3 (each within the scatter of the next).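

Fluoro in place of hydrogen on the aromatic carbon para to a large group, which turns the phenoxy group into a 4-fluorophenoxy group, gives a 1.1-fold higher number from compound 1 to compound 3 (0.02 log units; within the scatter) in this assay and so leaves the two compounds indistinguishable. Within the data shown here, this is the first measured pair here that differs in one place, and it shows that this position can carry one fluorine atom with no change in the number that can be told from the usual spread of repeat measurements. No separate measurement is available to explain this result.

The compounds shown leave open whether this position would respond in the same way to a group larger than fluoro or to one of a different kind, such as trifluoromethyl, methoxy, an amine or a carboxylic acid. They also leave open whether fluoro would give so small a step on other carbons of the same ring, or on the phenoxy group when the furan-bearing side chain of compound 1 is replaced.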